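The compounds below may be only part of what the source reports. "The series", "measured", "known", "first", "only" and "open" are said of these compounds alone.

Working notes on the series.

Of the compounds shown here, two of this set have been measured in a functional assay for agonist activity at Melanocyte-stimulating hormone receptor (Homo sapiens), read by cAMP accumulation; a higher number here means a larger maximal response, a lower number a smaller maximal response. Compound 1 `Cc1ccc(Cn2ccnc2NC(=O)[C@@H]2CN(C(C)(C)C)C[C@H]2c2ccc(F)cc2F)c(N2CCC(C(=O)O)CC2)c1` carries the extended benzyl substitution, and in this assay compound 1 gives 101%. Compound 2 `CC(C)(C)N1C[C@@H](C(=O)Nc2nccn2Cc2ccccc2)[C@H](c2ccc(F)cc2F)C1` keeps the shared core with a plain benzyl group, and in this assay compound 2 gives 54%. Compound 2 therefore stands lowest of the two measured values, with compound 1 the nearest, a number higher by a margin beyond the scatter.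

The step under consideration leads from compound 2 to compound 3 `CC(C)(C)N1C[C@@H](C(=O)Nc2nccn2Cc2ccccc2Cl)[C@H](c2ccc(F)cc2F)C1`. The change is chloro in place of hydrogen on an aromatic carbon. Going by the values given here, no measured pair in the set shows this same change, so no direct size for it is available from the data; the step from compound 2 to compound 3 is expected to be small, either within the scatter or a modest rise, with a drop in maximal response held less likely than a gain.

On that basis compound 3 is estimated at 62% in this assay, with a range from 40% to 88%, a step of a number 8 percentage points higher from compound 2 to compound 3 (within the scatter) relative to compound 2.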

Compound 3, intrinsic activity: the largest response reached, in percent of the reference agonist's: 65%
Beside the measured number, compound 3's estimate is 3 percentage points below it, and the stated range covers the measured number.
By their numbers in this assay, from the lowest: compound 2; then compound 3; then compound 1.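

In this assay, going by these compounds alone, chloro in place of hydrogen gives the first step that changes one place only: a number 11 percentage points higher from compound 2 to compound 3 (beyond the scatter), modest in size. It shows that benzyl to 2-chlorobenzyl, on an aromatic carbon ortho to a large group, is accepted at this position and raises the maximal response, so a substituent of one heavy atom on this ring is enough to move the number beyond the scatter. Nothing in the data shown accounts for this rise or links it to any property of the chloro group.

Whether the rise belongs to chlorine specifically or would also appear with another small group on the same carbon stays open, as fluoro, methyl, methoxy and nitrile are not among the compounds shown. Also open, from the compounds shown here alone, is whether chloro on the other carbons of this ring gives a step of like size, and whether the same change would still raise the response when carried on the extended benzyl substitution of compound 1.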